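The source may report more compounds than this note shows. Statements on the series, on what has been measured and on what is new or still open speak of the compounds shown alone.

Working notes on the series. In an ADME assay on Vero cells (Chlorocebus sabaeus) for cytotoxicity, read by sulforhodamine B assay, with a stated time of 48 h (on this read-out higher numbers stand for weaker inhibition of growth and lower numbers for stronger inhibition of growth), compound 1 `COc1ccc(/C(Cl)=C/C=C(\C#N)C(=O)c2c[nH]c3ccc(Br)cc23)cc1` gives "not determined" (no result reported) and compound 3 `COc1ccc(/C(Cl)=C/C=C(\C#N)C(=O)c2c[nH]c3ccccc23)cc1OC` gives "not determined" (no result reported); for each of them the measurement was not determined, so no number is reported. For the measured compounds named here, compound 2 `COc1cc(/C(Cl)=C/C=C(\C#N)C(=O)c2c[nH]c3ccc(Br)cc23)cc(OC)c1OC`, with three methoxy groups on one ring and a bromo on the fused ring, gives 7600 nM in this assay, and this is the only number in the set. Compound 3 thus stands nowhere on the numbers shown: it has no value of its own, and there is no second measured entry to set beside it.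

Compound 4 `COc1ccc(/C(Cl)=C/C=C(\C#N)C(=O)c2c[nH]c3ccc(Br)cc23)cc1OC` is compound 3 with the change (bromo in place of hydrogen on an aromatic carbon), bromo in place of hydrogen on an aromatic carbon, meta to a fused ring and para to a fused ring. Going by the values given here, no step between measured compounds covers this change, and compound 3 has no value, so no size or direction of step can be read from this assay; no step beyond the usual scatter is assumed in this assay for want of any pair that shows one. Among the compounds with values here, the only anchor is the compound that already carries the bromo on the fused ring. Because compound 2 gives 7600 nM with that bromo in place, compound 4 is expected to lie near it, estimated at 8000 nM, with a range of 2500 nM to 25000 nM.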

Compound 4, concentration for 50% growth inhibition: 8200 nM
Estimate against measurement, compound 4: 1.0-fold (0.01 log units) below; the measured number falls inside the stated range.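

In this assay, for the compounds shown here, the series now has its first readable step, a 1.1-fold higher number from compound 2 to compound 4 (0.03 log units; within the scatter), with hydrogen in place of methoxy on an aromatic carbon; with the bromo on the fused ring present in both compounds, this single change on the methoxy-bearing ring leaves the read-out within the scatter, which no earlier pair could show. The change from hydrogen to bromo itself, meta to a fused ring and para to a fused ring, cannot be read, and the same holds for every other step that would start from compound 1 or compound 3, as neither has a number. No measurement at hand bears on why the methoxy change leaves the read-out within the scatter.

Open, on these data alone, is whether the bromo moves the read-out at all, and whether a chloro, an amine or a carboxylic acid on that same aromatic carbon would give a number apart from the two now available. Also open, as far as these compounds go, is whether a hydroxyl or a longer chain such as ethoxy in place of a methoxy group would stay within the scatter as well.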